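The source may report more compounds than this note shows. Statements on the series, on what has been measured and on what is new or still open speak of the compounds shown alone.

Of the compounds shown here, three built on one shared core have been tested in an assay on isolated protein for inhibition of Dihydrofolate reductase (Homo sapiens), read by spectrophotometry, using NADPH, with stated times of 5 s and 6 min, tested at 5 uM; a lower number here means a weaker effect, a higher number a stronger effect of the compound at the concentration tested. Compound 1 `NC1=NC2(CCOCC2)N(OCCCOc2ccc(F)cc2)C(N)=N1` sits at a limit of the assay, > 90%, which is not a number. Compound 2 `Cc1ccc(OCCCON2C(N)=NC(N)=NC23CCOCC3)cc1` also sits at that limit, giving > 90%. Compound 3 `NC1=NC2(CCOCC2)N(OCCCOc2ccccc2Cl)C(N)=N1` is the only one of the three with a number shown, giving 83.3% in this assay. The two measured steps leading to compound 3 are a number at least 6.7 percentage points lower from compound 1 to compound 3 (that floor lies within the scatter) and a number at least 6.7 percentage points lower from compound 2 to compound 3 (that floor lies within the scatter); both floors lie within the scatter, and their true size stays hidden because of the limit of > 90% in this assay, at which 2 of the 3 values shown sit.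

Compound 4 `NC1=NC2(CCOCC2)N(OCCCOc2cccc(Br)c2)C(N)=N1` has not yet been measured. It differs from compound 3 in one place: 3-bromophenyl in place of 2-chlorophenyl on an oxygen on a saturated carbon. Among the compounds with values here, no measured step exchanges one halogen-bearing phenyl for another of this kind, so the two steps above only set a loose frame, and both of them were small at their readable floor. The step is therefore expected to stay within the scatter, a number 1.7 percentage points higher from compound 3 to compound 4 (within the scatter). Compound 4 is expected to give about 85% in this assay, between 70% and 95%.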

Compound 4, a percentage reported as inhibition, at one concentration (the size of the read-out at that concentration, not a potency): 86.7%
Compound 4: middle estimate off by 1.7 percentage points, on the low side, and the stated range covers the measured number.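

Within the data shown here, this is the first step on this phenyl group, on an oxygen on a saturated carbon, with a readable size at both ends: in this assay, the change to 3-bromophenyl gives a number 3.4 percentage points higher from compound 3 to compound 4 (within the scatter). Exchanging these two halogen-bearing phenyl groups therefore produces no difference that can be told from the scatter. The other two new steps are a number at least 3.3 percentage points lower from compound 2 to compound 4 (that floor lies within the scatter) and a number at least 3.3 percentage points lower from compound 1 to compound 4 (that floor lies within the scatter), and their true size cannot be read: the limit of > 90% in this assay, at which 2 of the 4 values shown sit.

From the compounds shown here alone, whether an amine or a carboxylic acid on the phenyl ring, or a longer chain to the oxygen, would give a step beyond the scatter stays open. Going by these compounds, a read-out at one concentration is also not a potency, so any difference in potency between compound 3 and compound 4 remains unknown.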